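This account rests on a few compounds, and the source may have more. Where it says the series, first, only, none or still open, it means among the compounds named here.

Measured so far in a functional assay on NCI-H460 cells (Homo sapiens) for antiproliferative activity, read by MTT assay, with a stated time of 72 h; a higher number here means a weaker inhibitor, a lower number a stronger inhibitor:

Compound 1, `CCN(CC)CCn1cnnc1-c1cc(Oc2ccc(NC(=O)Nc3ccc(F)c(F)c3)cc2F)ccn1`, gives 14900 nM.
Compound 2, `CCN(CC)CCn1cnnc1-c1cc(Oc2ccc(NC(=O)Nc3ccc(F)c(Cl)c3)cc2F)ccn1`, gives 7390 nM.
Compound 3, `CN(C)CCCn1cnnc1-c1cc(Oc2ccc(NC(=O)Nc3ccc(F)c(F)c3)cc2F)ccn1`, gives 1080 nM.

Compound 4, `CN(C)CCCn1cnnc1-c1cc(Oc2ccc(NC(=O)Nc3ccc(F)c(Cl)c3)cc2F)ccn1`, has not yet been measured in this assay.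

Between compound 1 and compound 2 the change is chloro in place of fluoro on an aromatic carbon, and it made a 2.0-fold lower number from compound 1 to compound 2 (0.30 log units; within the scatter). Compound 4 carries the same change relative to compound 3, (chloro in place of fluoro on an aromatic carbon), at a place described in identical terms. The two cores differ by (dimethylamino)methyl in place of diethylamino on a saturated chain carbon, two bonds along the chain from an aromatic nitrogen, which made a 14-fold lower number from compound 1 to compound 3 (1.14 log units; beyond the scatter); compound 3 thus stands lowest of the three measured numbers.

For compound 4 a step of about a 2.0-fold lower number from compound 3 to compound 4 (0.30 log units; within the scatter) is expected, resting on the earlier 2.0-fold lower number from compound 1 to compound 2 (0.30 log units; within the scatter) seen on the other core. Compound 4 is therefore estimated at 540 nM, with a likely range from 250 nM to 1200 nM.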

Compound 4, half-maximal inhibitory concentration: 1270 nM
For compound 4 the middle estimate is 2.4-fold (0.37 log units) below the measured one; measured number above the stated range.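

In this assay, chloro in place of fluoro gives a 1.2-fold higher number from compound 3 to compound 4 (0.07 log units; within the scatter), and the step does not differ between the two cores: the same change on two cores in this assay, a 2.0-fold lower number (0.30 log units; within the scatter) from compound 1 to compound 2 and a 1.2-fold higher number (0.07 log units; within the scatter) from compound 3 to compound 4, 2.4-fold (0.37 log units) apart, within the scatter of two such steps

(Dimethylamino)methyl in place of diethylamino gives a 5.8-fold lower number from compound 2 to compound 4 (0.76 log units; beyond the scatter), and this step also holds across the 3,4-difluorophenyl and 3-chloro-4-fluorophenyl compounds: the same change on two cores in this assay, a 14-fold lower number (1.14 log units; beyond the scatter) from compound 1 to compound 3 and a 5.8-fold lower number (0.76 log units; beyond the scatter) from compound 2 to compound 4, 2.4-fold (0.37 log units) apart, within the scatter of two such steps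

Both changes therefore carry over on these two cores, but the halogen change has no effect distinguishable from scatter, and a single pair of cores sets no rule for the wider series.

Still open, on these data alone, is whether bromo or methyl in place of that chloro, or a morpholine or pyrrolidine in place of the dimethylamino group, would carry over in the same way.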